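This account rests on a few compounds, and the source may have more. Where it says the series, first, only, none or still open, it means among the compounds named here.

Measured compounds:

- compound 1 `O=[N+]([O-])c1ccc(C(c2c[nH]c3ccc(Br)cc23)c2c[nH]c3ccc(Br)cc23)cc1`, 3100 nM
- compound 2 `CCCCCCCC(c1c[nH]c2ccc(Br)cc12)c1c[nH]c2ccc(Br)cc12`, 5500 nM
- compound 3 `N#Cc1ccc2[nH]cc(C(c3ccc([N+](=O)[O-])cc3)c3c[nH]c4ccc(C#N)cc34)c2c1`, 23600 nM

All three were tested in a functional assay on MCF7 cells (Homo sapiens) for inhibition, read by MTT assay, with a stated time of 48 h; a higher number here means a weaker inhibitor, a lower number a stronger inhibitor. Compound 1 and compound 2 share a core and differ only by the change (heptyl in place of 4-nitrophenyl on a saturated chain carbon bound to two aromatic carbons); the step of a 1.8-fold higher number from compound 1 to compound 2 (0.25 log units; within the scatter) is within the scatter, so the two readings are treated as equivalent. Compound 3 carries a different core; the difference between the two cores is not broken down here. Compound 3 gives the highest number of the three, and its gaps to compound 2 and to compound 1 are both beyond the scatter, so within this small set it is the weakest inhibitor.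

Compound 4 `CCCCCCCC(c1c[nH]c2ccc(C#N)cc12)c1c[nH]c2ccc(C#N)cc12` is not yet measured. It is derived from compound 3 by heptyl in place of 4-nitrophenyl on a saturated chain carbon bound to two aromatic carbons, which is the same change as made from compound 1 to compound 2, at the same place. Within the data shown here, the only precedent for this change is the step of a 1.8-fold higher number from compound 1 to compound 2 (0.25 log units; within the scatter), which is within the scatter. For compound 4 the expected step is therefore a 1.7-fold higher number from compound 3 to compound 4 (0.23 log units; within the scatter), resting on the behaviour of compound 2 relative to compound 1 and on the starting point set by compound 3. Among the measured compounds shown here, on that basis compound 4 is estimated at 40000 nM in this assay, with a likely range from 15000 nM to 110000 nM; the range is widened because the change is carried over to a different core with only one measured example behind it.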

Compound 4, half-maximal inhibitory concentration: 2500 nM
For compound 4 the middle estimate is 16-fold (1.20 log units) above the measured one; measured number below the stated range.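

In this assay, heptyl in place of 4-nitrophenyl on a saturated chain carbon bound to two aromatic carbons gives a 9.4-fold lower number from compound 3 to compound 4 (0.97 log units; beyond the scatter) and so yields a stronger inhibitor on the core of compound 3. The change therefore does not carry over with a constant size from one core to the other, and the step on the core of compound 1 gives no reliable guide to the step on the core of compound 3: the same change on two cores in this assay, a 1.8-fold higher number (0.25 log units; within the scatter) from compound 1 to compound 2 and a 9.4-fold lower number (0.97 log units; beyond the scatter) from compound 3 to compound 4, 17-fold (1.22 log units) apart, beyond the scatter of two such steps. This does not show why the two cores differ or how the change would behave on a third core, and the comparison rests on a single pair for each core.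

The compounds shown leave open whether the response on the core of compound 3 depends on heptyl itself, or whether a shorter or longer alkyl chain, or an unsubstituted phenyl, would give a similar step on each core. Also open, from the compounds shown here alone, is whether an amine or a carboxylic acid at the end of the chain would preserve the inhibition seen with compound 4, and whether the gap between the two steps would persist with any of these groups.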